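Para substituent on the thiazole-attached phenyl: fluoro, hydrogen, nitro

A few compounds are considered here, and "the series" means these few. Any claim that something is new, unique, unknown or untested is made for them only; others in the source may bear on it.

Measured so far:
compound 1 `Cc1ccc(C2=NN(c3nc(-c4ccc(F)cc4)cs3)C(c3ccc(F)cc3)C2)s1`, 125 ug/mL in a functional assay on A549 cells (Homo sapiens) for antiproliferative activity, read by XTT assay, with a stated time of 24 h; a higher number here means a weaker inhibitor, a lower number a stronger inhibitor
compound 2 `Cc1ccc(C2=NN(c3nc(-c4ccccc4)cs3)C(c3ccc(F)cc3)C2)s1`, > 500 ug/mL in this assay

Compound 2 gives only a limit in this assay, (the limit of > 500 ug/mL in this assay, at which 1 of the 2 values shown sits). For the measured compounds named here, the one measured step, an at least 4.0-fold higher number from compound 1 to compound 2 (0.60 log units; beyond the scatter), shows that removing the para fluoro weakened inhibition at least modestly. Compound 3 `Cc1ccc(C2=NN(c3nc(-c4ccc([N+](=O)[O-])cc4)cs3)C(c3ccc(F)cc3)C2)s1` differs from compound 2 by nitro in place of hydrogen on an aromatic carbon. Going by the values given here, no measured step covers a nitro at this position, so the direction is uncertain; a para group did help in compound 1, so compound 3 is expected to move back toward a measurable value, an at least 2.5-fold lower number from compound 2 to compound 3 (0.39 log units; beyond the scatter). Compound 3 is estimated at 200 ug/mL, between 60 ug/mL and 600 ug/mL.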

Compound 3, half-maximal inhibitory concentration: 16.7 ug/mL
Compound 3: the middle estimate sits 12-fold (1.08 log units) above what was measured; measured number outside the range, below it.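

In this assay, the position para to a large group separates the compounds more widely than the fluoro and hydrogen pair showed: phenyl to 4-nitrophenyl gives an at least 29-fold lower number from compound 2 to compound 3 (1.47 log units; beyond the scatter), and nitro also outperforms fluoro, with a 7.5-fold lower number from compound 1 to compound 3 (0.87 log units; beyond the scatter). Compound 2 stands only as a limit, so the first of these steps is a bound: the limit of > 500 ug/mL in this assay, at which 1 of the 3 values shown sits. Among these three compounds, compound 3 is the strongest inhibitor, and the order nitro, fluoro, hydrogen holds for them alone.

On these data alone, whether this gain is particular to nitro remains open. An amine, a carboxylic acid or a methoxy group at this place could show how far it extends.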